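Trimethoxyphenyl hydrazone and pyrazoline series: antiproliferative screen

The compounds below may be only part of what the source reports. "The series", "measured", "known", "first", "only" and "open" are said of these compounds alone.

Measured compounds:
compound 1 `COc1ccc(C2OC(c3cc(OC)c(OC)c(OC)c3)=NN2C(C)=O)c(OC)c1`: -3.1%
compound 2 `COc1cc(C(=O)N/N=C/c2ccc(Cl)c([N+](=O)[O-])c2)cc(OC)c1OC`: 2.3%
compound 3 `COc1cc(C(=O)N/N=C/c2c(Cl)cccc2Cl)cc(OC)c1OC`: 27.8%

In a functional assay on BGC-823 cells (Homo sapiens) for antiproliferative activity, read by MTT assay, tested at 5 uM (a lower number here means a weaker effect, a higher number a stronger effect of the compound at the concentration tested), compound 1 gives -3.1%, the lowest of the three numbers. Compound 2 gives 2.3%, which lies within the scatter of compound 1. Compound 3 gives 27.8%, a gap from compound 1 that is beyond the scatter; with only these two points no rule for the series is claimed.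

Compound 4 `COc1cc(C2=NN(C(C)=O)C(c3ccc(C(F)(F)F)cc3)O2)cc(OC)c1OC` keeps the shared core of compound 1 and differs in one place: 4-(trifluoromethyl)phenyl in place of 2,4-dimethoxyphenyl on a saturated ring carbon. No step between measured compounds bears directly on this exchange, so the expectation rests on compound 1 alone and on the small spread among the pyrazoline and hydrazone numbers shown. The expected step is a number 9.1 percentage points higher from compound 1 to compound 4 (within the scatter), a small rise that stays within the scatter rather than a clear gain in this assay.

For compound 4 the estimate is 6%, with a likely range from -6% to 20%.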

Compound 4, a percentage reported as inhibition, at one concentration (the size of the read-out at that concentration, not a potency): 3.4%
Compound 4: the middle estimate sits 2.6 percentage points above what was measured, and the stated range covers the measured number.
By their numbers in this assay, from the lowest: compounds 1, 2 and 4 (each within the scatter of the next); then compound 3.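

On the saturated ring carbon of the shared core, in this assay, 4-(trifluoromethyl)phenyl in place of 2,4-dimethoxyphenyl gives a number 6.5 percentage points higher from compound 1 to compound 4 (within the scatter), the first step read at this position. The two groups match in heavy atoms and in their aromatic ring, but only the leaving group carries hydrogen-bond acceptors, and this exchange does not separate the two compounds in this read-out. No measured evidence bears on this result.

Still open, on these data alone, is whether any group on this phenyl ring, such as an amine or a carboxylic acid, would move the number beyond the scatter of compound 1. Also open, as far as these compounds go, is whether a butanoyl group in place of the acetyl group on the ring atom would change the read-out of either compound.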